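This account rests on a few compounds, and the source may have more. Where it says the series, first, only, none or still open, it means among the compounds named here.

Measured in a functional assay on HCT-116 cells (Homo sapiens) for antiproliferative activity, read by MTT assay, with a stated time of 72 h; a higher number here means a weaker inhibitor, a lower number a stronger inhibitor:
- compound 1 `COc1cccc(C(=O)N(C)c2ccc3[nH]c(-c4n[nH]c5ccccc45)cc3n2)c1`: 14200 nM
- compound 2 `CN(c1ccc2[nH]c(-c3n[nH]c4ccccc34)cc2n1)S(=O)(=O)c1ccccc1`: 6740 nM

Compound 2 gives the lower of these two numbers, 6740 nM. Compound 3 `CN(c1ccc2[nH]c(-c3n[nH]c4ccccc34)cc2n1)S(=O)(=O)c1cccc([N+](=O)[O-])c1` differs from it by one change, nitro in place of hydrogen on an aromatic carbon. Among the measured compounds shown here, the only measured step, a 2.1-fold lower number from compound 1 to compound 2 (0.32 log units; beyond the scatter), was modest and replaced the whole group on the nitrogen. It says nothing directly about adding nitro, so no direction can be read from the data, and no step beyond the scatter is expected in this assay. The expected change is small: a 1.1-fold lower number from compound 2 to compound 3 (0.05 log units; within the scatter). For compound 3 the estimated value is 6000 nM, with an expected range of 2000 nM to 18000 nM.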

Compound 3, half-maximal inhibitory concentration: 13600 nM
The estimate for compound 3 lay 2.3-fold (0.36 log units) below the measured number; the measured number falls inside the stated range.
By their numbers in this assay, from the lowest: compounds 2, 3 and 1 (each within the scatter of the next, the first and the last beyond it).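

In this assay, among the compounds shown here, the change from phenyl to 3-nitrophenyl gives a 2.0-fold higher number from compound 2 to compound 3 (0.30 log units; within the scatter) and is the first measured substitution on this ring. At this ring carbon, a nitro group with its 3 heavy atoms therefore produces no step beyond the usual scatter, so compound 2 and compound 3 cannot be ranked. On these data alone, whether an amine or a carboxylic acid at the same carbon would also stay within the scatter remains open, as does the effect of nitro on another carbon of this ring. No measurement shown offers an explanation for this result.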